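A second fluoro and the cytotoxicity limit

This account rests on a few compounds, and the source may have more. Where it says the series, first, only, none or still open, it means among the compounds named here.

Measured in an ADME assay on HepG2 cells (Homo sapiens) for cytotoxicity, with a stated time of 72 h; on this read-out higher numbers stand for an effect only at larger amounts of compound and lower numbers for an effect already at smaller amounts:
compound 1 `Cc1cc(NC(=O)Nc2cccc([N+](=O)[O-])c2)c2ccccc2n1` gives > 25000 nM as a limit
compound 2 `Cc1cc(NC(=O)Nc2cccc(F)c2)c2ccccc2n1` gives > 25000 nM as a limit
compound 3 `COc1ccc(NC(=O)Nc2cc(C)nc3ccccc23)cc1F` gives > 25000 nM as a limit

Compound 2 has no exact number, only the limit > 25000 nM in this assay. For the measured compounds named here, the measured series shares one mark, (the limit of > 25000 nM in this assay, at which 3 of the 3 values shown sit), so no compound can be ranked against another.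

Compound 4 `Cc1cc(NC(=O)Nc2cc(F)cc(F)c2)c2ccccc2n1` differs from compound 2 in one place: fluoro in place of hydrogen on an aromatic carbon. Two measured changes bear on it: a step that the two limits leave unreadable from compound 1 to compound 2, with fluoro in place of nitro, and a step that the two limits leave unreadable from compound 2 to compound 3, with methoxy in place of hydrogen. Neither has a readable size, but all three compounds stayed at the limit, so no step beyond the usual scatter is expected in this assay. The expected step is a number no higher from compound 2 to compound 4 (the limit leaves the size open), and the assay will probably report only a limit again. For compound 4 the estimate is 25000 nM, within an expected range from 14000 nM to 50000 nM.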

Compound 4, half-maximal effective concentration: > 25000 nM
Compound 4: only a limit was reported (the forecaster's own chance of this, stated with the estimate: 85%); the middle value sits exactly at the limit.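

In this assay, for the compounds shown here, compound 2 and compound 4 each give only a limit, so no step between them can be read: the limit of > 25000 nM in this assay, at which 4 of the 4 values shown sit. The compounds shown leave open at what concentration any of them would affect these cells.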